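Ethyl esters on a pyridopyrimidine hydrazone series in the rat

The compounds below may be only part of what the source reports. "The series", "measured", "known", "first", "only" and "open" are said of these compounds alone.

Compound 1 `CC1CC/C(=N\Nc2ccccc2O)c2ncc(C(=O)O)c(=O)n21` was tested in a functional assay on the whole organism for inhibition, with Rattus norvegicus as the target; a lower number here means that less compound is needed, a higher number that more compound is needed for the effect. In this assay compound 1 gives > 100 umol/kg, which is a limit of the assay rather than a number. Compound 2 `CCOc1ccccc1N/N=C1\CCC(C)n2c1ncc(C(=O)O)c2=O` differs from compound 1 by ethyl in place of hydrogen on an oxygen on an aromatic ring. In this assay compound 2 gives > 1000 umol/kg, again a limit. The step that the two limits leave unreadable from compound 1 to compound 2 therefore cannot be read. Compound 3 `CC1CC/C(=N\Nc2cccc(C(=O)O)c2)c2ncc(C(=O)O)c(=O)n21` carries a different core; the difference between the two cores is not broken down here. In this assay compound 3 gives > 100 umol/kg, once more a limit. Compound 4 `CCOC(=O)c1cccc(N/N=C2\CCC(C)n3c2ncc(C(=O)O)c3=O)c1` has not been measured; it differs from compound 3 by ethyl in place of hydrogen on an oxygen next to a carbonyl group. The place is not the same as in the earlier pair, where the oxygen sits on an aromatic ring rather than on an oxygen next to a carbonyl group, so this is the same kind of change, not the same change. Compound 4 is expected to show a step that the limit leaves unreadable from compound 3 to compound 4, which rests on compound 3 sitting at the limit (the limit of > 100 umol/kg in this assay, at which 2 of the 3 values shown sit). Compound 4 is estimated at 300 umol/kg, between 60 umol/kg and 3000 umol/kg, and most likely a limit again.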

Compound 4, dose for 50% inhibition: > 100 umol/kg
Compound 4: no number, only a limit; the forecaster's own chance of this, stated with the estimate: 85%; the middle value is on the limit's open side.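

In this assay compound 3 and compound 4 each give only a limit of the assay rather than a number, so the step between these two compounds cannot be read: the limit of > 100 umol/kg in this assay, at which 3 of the 4 values shown sit. The compounds shown leave open what dose of any of them gives the effect, and whether placing ethyl on the oxygen changes that dose at all.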